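The source may hold more compounds than are shown below. What is called first, only, known or untested is meant among the compounds shown, and "the series" means these compounds.

Measured so far:
compound 1 `CC1=C(O)/C(=C/[C@H](C)CCC/C(C)=C/CCc2coc(Cc3ccoc3)c2)OC1=O` gives 8.95 ug/mL in a functional assay on SK-MEL-2 cells (Homo sapiens) for cytotoxicity; on this read-out lower numbers stand for an effect already at smaller amounts and higher numbers for an effect only at larger amounts of compound
compound 2 `CC1=C(O)/C(=C/[C@H](C)CC/C=C(/C)CCCc2coc(Cc3ccoc3)c2)OC1=O` gives 5.87 ug/mL in this assay

Compound 1 carries the highest of the two numbers; the nearest is compound 2, and the gap between the two values lies within the scatter, so the pair shows no difference. Among the measured compounds shown here, no step between measured compounds is known for the change at hand. Compound 3 `CC1=C(O)/C(=C\[C@H](C)CCC/C(C)=C/CCc2coc(Cc3ccoc3)c2)OC1=O` differs from compound 1 as follows: the two compounds have the same atoms and bonds and differ only in configuration as drawn: 1 of 3 stereo elements differ; a double bond is drawn Z in compound 1 and E in compound 3. For the measured compounds named here, with no measured step of this kind, no direction is expected beyond the scatter. The value estimated for compound 3 is 9 ug/mL with a range of 3 ug/mL to 27 ug/mL, the expected step being a 1.0-fold higher number from compound 1 to compound 3 (0.00 log units; within the scatter).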

Compound 3, concentration for half-maximal effect: 10.2 ug/mL
Compound 3: the middle estimate sits 1.1-fold (0.05 log units) below what was measured, within the range that was stated.
By their numbers in this assay, from the lowest: compounds 2, 1 and 3 (each within the scatter of the next).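

In this assay, switching this double bond from Z to E gives a 1.1-fold higher number from compound 1 to compound 3 (0.06 log units; within the scatter). Among the compounds shown here, this is the first step measured at this position, and it shows no difference that can be told from the scatter, so the drawn geometry of this double bond has no visible bearing on the read-out in this pair. The comparison rests on a single change: the fact that compounds 1 and 3 differ only in the configuration as drawn

Going by these compounds, whether the same switch would be equally silent in compound 2 remains open. So does the effect of a longer chain or of a carboxylic acid on the chain.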